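Series notes: diol chain in place of amino chain

The source may report more compounds than this note shows. Statements on the series, on what has been measured and on what is new or still open speak of the compounds shown alone.

Three compounds share one core and differ only at the end of the chain attached through an oxygen to the aromatic ring. In a functional assay (Homo sapiens) for antiproliferative activity, read by resazurin assay, with a stated time of 48 h, tested at 20 uM (on this read-out lower numbers stand for a weaker effect and higher numbers for a stronger effect at the one concentration tested), compound 1 `COc1cc(OC)c2c(=O)cc(-c3ccc(OCCBr)cc3)oc2c1` gives 20%, compound 2 `COc1cc(OC)c2c(=O)cc(-c3ccc(OCCF)cc3)oc2c1` gives 21%, and compound 3 `COc1cc(OC)c2c(=O)cc(-c3ccc(OCCN)cc3)oc2c1` gives 70%, the highest of the three. The step of a number 1 percentage points higher from compound 1 to compound 2 (within the scatter) is small, whereas a number 50 percentage points higher from compound 1 to compound 3 (beyond the scatter) and a number 49 percentage points higher from compound 2 to compound 3 (beyond the scatter) are both large, and in both the entering group is amino. Compound 4 `COc1cc(OC)c2c(=O)cc(-c3ccc(OCC(O)CO)cc3)oc2c1` carries 1,2-dihydroxyethyl in place of aminomethyl on a saturated chain carbon bound to an oxygen on an aromatic ring. Within the data shown here, no measured step leads to the 1,2-dihydroxyethyl group itself, so with the amino group gone a return toward the lower values of compound 1 and compound 2 is expected, with wide uncertainty. Compound 4 is expected at 35%, between 15% and 60%, that is a number 35 percentage points lower from compound 3 to compound 4 (beyond the scatter).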

Compound 4, a percentage reported as inhibition, at one concentration (the size of the read-out at that concentration, not a potency): 16%
Compound 4: middle estimate off by 19 percentage points, on the high side, and the stated range covers the measured number.
By their numbers in this assay, from the lowest: compounds 4, 1 and 2 (each within the scatter of the next); then compound 3.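

The 2,3-dihydroxypropoxy chain does not take over the role of the 2-aminoethoxy chain at this position, with a number 54 percentage points lower from compound 3 to compound 4 (beyond the scatter), so hydroxyl groups on the chain do not keep what the amino end group gave. The diol instead falls level with the halides, with a number 5 percentage points lower from compound 2 to compound 4 (within the scatter) and a number 4 percentage points lower from compound 1 to compound 4 (within the scatter), leaving amino as the only one of these four end groups that stands apart. No evidence on the cause is at hand.

Going by these compounds, whether this depends on the amine as such stays open. A dimethylamino end group, a carboxylic acid or a 3-aminopropoxy chain would test that.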